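Solubility across the ring-nitrogen substituent of the series

A few compounds are considered here, and "the series" means these few. Any claim that something is new, unique, unknown or untested is made for them only; others in the source may bear on it.

Compound 2 `CNC(=O)c1cc(C(=O)NC2CC2)cn(CC2CCOCC2)c1=O` carries an (oxan-4-yl)methyl group on the aromatic nitrogen of the shared core. In a physicochemical assay for solubility (a lower number here means a less soluble compound, a higher number a more soluble compound), compound 2 returns only a limit, >= 165 ug/mL; this is the limit of >= 165 ug/mL in this assay, at which 1 of the 3 values shown sits. Compound 3 `CNC(=O)c1cc(C(=O)NC2CC2)cn([C@H](C)c2ccccc2)c1=O` likewise returns only a limit in this assay, >= 168 ug/mL, which is the limit of >= 168 ug/mL in this assay, at which 1 of the 3 values shown sits. The step that the two limits leave unreadable from compound 2 to compound 3 is therefore not readable from the two limits. For the measured compounds named here, compound 1 `CNC(=O)c1cc(C(=O)NC2CCC2)cn(Cc2ccccc2)c1=O`, with a benzyl group and a cyclobutyl amide, gives a number in this assay, 28 ug/mL; no step between compound 1 and compound 2 is computed, so the two values can only be set side by side.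

Compound 4 `CNC(=O)c1cc(C(=O)NC2CC2)cn(Cc2cccc3[nH]ncc23)c1=O` is not yet measured. Against compound 2 the change is 1H-indazol-4-yl in place of oxan-4-yl on a saturated chain carbon bound to an aromatic nitrogen. Going by the values given here, no measured step reads across to this change: the one computed step is unreadable, and no step toward a bicyclic aromatic group exists among the three values. Compound 4 is expected to fall toward a number rather than a limit because compound 1 gives 28 ug/mL, and the estimate for compound 4 in this assay is 40 ug/mL, within 10 ug/mL to 150 ug/mL. For compound 4 the implied step an at least 4.1-fold lower number from compound 2 to compound 4 (0.61 log units; beyond the scatter) is expected downward. From the compounds shown here alone, compound 2 stands at a limit; the true size of that step therefore remains open.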

Compound 4, solubility: 10 ug/mL
Estimate against measurement, compound 4: 4.0-fold (0.60 log units) above; the measured number falls inside the stated range.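

In this assay, for the compounds shown here, replacing oxan-4-yl with 1H-indazol-4-yl on a saturated chain carbon bound to an aromatic nitrogen gives an at least 16-fold lower number from compound 2 to compound 4 (1.21 log units; beyond the scatter) and is the first readable step at this position. With the cyclopropyl amide and the rest of the shared core unchanged, the change of this one group is enough to move the series from a limit of the assay to a number, a shift that the earlier pair of limits could not show. The printed size of the step is only a bound, because the starting point is a limit and not a number: the limit of >= 165 ug/mL in this assay, at which 1 of the 4 values shown sits.

The compounds shown do not say whether the step belongs to the 1H-indazol-4-yl group as a whole, to its five-membered ring with the hydrogen-bond donor, or to its six-membered carbon ring, and they give no cause for it. From the compounds shown here alone, how far the number moves with other groups at this place, such as a pyridinyl group, a morpholine or a carboxylic acid, also remains open.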